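Benzyl on the imine nitrogen of a quinolinone core

The source may hold more compounds than are shown below. What is called first, only, known or untested is meant among the compounds shown, and "the series" means these compounds.

Measured compounds:
`O=c1[nH]c2ccccc2cc1/C=N/Cc1ccccc1` compound 1, "not active" (no number reported) in a functional assay, read by spectrophotometry, with a stated time of 30 min; on this read-out lower numbers stand for stronger inhibition and higher numbers for weaker inhibition
`Cc1ccc2[nH]c(=O)c(/C=N/O)cc2c1` compound 2, 160000 nM
`Cc1ccc2[nH]c(=O)c(/C=N/N)cc2c1` compound 3, 641000 nM

Compound 3 gives the highest number of the two measured values in this assay; compound 2 stands nearest, with a 4.0-fold higher number from compound 2 to compound 3 (0.60 log units; beyond the scatter). Compound 4, `Cc1ccc2[nH]c(=O)c(/C=N/Cc3ccccc3)cc2c1`, differs from compound 3 by benzyl in place of amino on a double-bonded nitrogen. No measured step covers this change; the single step shown runs from hydroxy to amino on the same nitrogen, and compound 1, which carries a benzyl there on a core lacking the methyl, gives no number at all in this assay. Compound 4 is therefore expected to fall at a still higher number, a 2.3-fold higher number from compound 3 to compound 4 (0.37 log units; beyond the scatter), with a fair chance that only a limit is reported. The estimate for compound 4 is 1500000 nM, between 300000 nM and 8000000 nM.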

Compound 4, half-maximal inhibitory concentration: "not active" (no number reported)
Compound 4: no number reported, so the estimate cannot be set against anything.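

In this assay, among the compounds shown here, compound 4 gives "not active" (no number reported) and so, like compound 1, yields no number, and no step from compound 3 can be read. The compounds shown leave open how benzyl on the double-bonded nitrogen compares numerically with amino or hydroxy there. No measurement shown bears on a cause.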